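This account rests on a few compounds, and the source may have more. Where it says the series, first, only, none or still open, it means among the compounds named here.

Of the compounds shown here, two of a shared dihydropyridine-type core have been measured so far. Compound 1 `COC(=O)C1=C(C)NC(C)=C(C(=O)OC2Cc3ccccc3C2)C1c1cccc([N+](=O)[O-])c1` gives 72 nM in a functional assay on HEK293 cells for antagonist activity at Voltage-dependent L-type calcium channel subunit alpha-1C (Oryctolagus cuniculus), read by FLIPR; on this read-out higher numbers stand for weaker inhibition and lower numbers for stronger inhibition. For the measured compounds named here, compound 2 `COC(=O)C1=C(C)NC(C)=C(C(=O)OCCOc2ccccc2Cl)C1c1cccc([N+](=O)[O-])c1` gives 19 nM in this assay, and so stands at the lower of the two numbers; the only measured step, a 3.8-fold lower number from compound 1 to compound 2 (0.58 log units; beyond the scatter), is the swap of the ester side chain. Compound 3 `COC(=O)C1=C(C)NC(C)=C(C(=O)OCCCCc2ccccc2)C1c1cccc([N+](=O)[O-])c1` differs from compound 2 by phenethyl in place of 2-chlorophenoxy on a saturated chain carbon, two bonds along the chain from an oxygen next to a carbonyl group. Going by the values given here, no measured step touches this exact change; the step from compound 1 to compound 2 only shows that altering the ester side chain can move the number by a modest amount. For compound 3 a small shift, most likely a slightly higher number but not clearly beyond the scatter, is therefore expected, a 1.6-fold higher number from compound 2 to compound 3 (0.20 log units; within the scatter). The estimate for compound 3 in this assay is 30 nM, with a range from 10 nM to 90 nM.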

Compound 3, half-maximal inhibitory concentration: 10 nM
Compound 3: middle estimate off by 3.0-fold (0.48 log units), on the high side, and the stated range covers the measured number.
By their numbers in this assay, from the lowest: compounds 3 and 2 (each within the scatter of the next); then compound 1.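

In this assay the swap of the ether side chain for an all-carbon one is a 1.9-fold lower number from compound 2 to compound 3 (0.28 log units; within the scatter) and so cannot be told apart from no change, even though phenethyl carries no chlorine and no hydrogen-bond acceptor. This shows that, at this place on the chain, 2-chlorophenoxy can give way to phenethyl without a change beyond the scatter. The step of a 7.2-fold lower number from compound 1 to compound 3 (0.86 log units; beyond the scatter) shows that compound 1 stands apart from compound 3 as well as from compound 2, and nothing at hand gives a reason for these results.

Oxygen and chlorine left together in this swap. A plain 2-phenoxyethyl side chain would be needed to separate them. Going by these compounds, whether a chain longer than 4-phenylbutyl, or an amine placed in the side chain, keeps the number this low remains open.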